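A few compounds are considered here, and "the series" means these few. Any claim that something is new, unique, unknown or untested is made for them only; others in the source may bear on it.

Three compounds share one core and differ only in the group on the carbonyl carbon. In a functional assay on OVCAR-4 cells (Homo sapiens) for cytotoxicity, read by sulforhodamine B assay, with a stated time of 48 h, tested at 100 uM (on this read-out higher numbers stand for a weaker effect at the one concentration tested and lower numbers for a stronger effect), compound 1 `COc1cc(-c2cc(/C=C/C(=O)c3ccc(N)cc3)[nH]n2)cc(OC)c1OC` gives -96%, compound 2 `COc1cc(-c2cc(/C=C/C(=O)c3ccc(Cl)c(Cl)c3)[nH]n2)cc(OC)c1OC` gives -22%, and compound 3 `COc1ccc(C(=O)/C=C/c2cc(-c3cc(OC)c(OC)c(OC)c3)n[nH]2)cc1` gives -15%. Compound 3 thus has the highest of the three numbers, close to compound 2 and far from compound 1. Compound 4 `COc1cc(-c2cc(/C=C/C(=O)c3ccc(F)c(F)c3)[nH]n2)cc(OC)c1OC` differs from compound 3 by 3,4-difluorophenyl in place of 4-methoxyphenyl on a carbonyl carbon. Because compound 2 gives -22% with 3,4-dichlorophenyl on that same carbon, the step of a number 7 percentage points higher from compound 2 to compound 3 (within the scatter) bears most on this change; the large step of a number 74 percentage points higher from compound 1 to compound 2 (beyond the scatter) concerns the amino group, which is not involved here. A step of a number 5 percentage points lower from compound 3 to compound 4 (within the scatter) is therefore expected, not beyond the scatter. Compound 4 is estimated at -20%, between -55% and 10%.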

Compound 4, a percentage reported as activity, at one concentration (the size of the read-out at that concentration, not a potency): -3%
Compound 4: the middle estimate sits 17 percentage points below what was measured; measured number inside the range.
By their numbers in this assay, from the lowest: compound 1; then compounds 2 and 3 (each within the scatter of the next); then compound 4.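

In this assay the change to 3,4-difluorophenyl on the carbonyl carbon gives a number 12 percentage points higher from compound 3 to compound 4 (beyond the scatter) and also a number 19 percentage points higher from compound 2 to compound 4 (beyond the scatter), so this position separates groups other than 4-aminophenyl, the only one that had stood apart so far. For the compounds shown here, compound 4 has the weakest effect of the set, and the widest gap remains the one to the amino compound, with a number 93 percentage points higher from compound 1 to compound 4 (beyond the scatter) in this assay. Nothing measured here explains these steps.

Open, as far as these compounds go, is how an unsubstituted phenyl or a monofluorophenyl would read on that carbon. Also open, from the compounds shown here alone, is whether an acetamide or a dimethylamino group could replace the amino group of compound 1 and keep its strong effect.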